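This account rests on a few compounds, and the source may have more. Where it says the series, first, only, none or still open, it means among the compounds named here.

Measured in a functional assay on DU-145 cells (Homo sapiens) for antiproliferative activity, read by MTT assay, with a stated time of 48 h; a lower number here means a stronger inhibitor, a higher number a weaker inhibitor:
- Compound 1 `C/C(=C\CC/C(C)=C/CC[C@@H]1[C@@]2(C)CCC(=O)C(C)(C)[C@H]2CC[C@@]1(C)O)CC/C=C(\C)C(=O)OCc1cn(-c2cccc(Br)c2)nn1`: > 150000 nM (a limit)
- Compound 2 `C/C(=C\CC/C(C)=C/CC[C@@H]1[C@@]2(C)CCC(=O)C(C)(C)[C@H]2CC[C@@]1(C)O)CC/C=C(\C)C(=O)OCc1cn(-c2ccc(Cl)cc2)nn1`: > 150000 nM (a limit)

Compound 2 has no number of its own, only the limit > 150000 nM. The same holds across the short series, which shows (the limit of > 150000 nM in this assay, at which 2 of the 2 values shown sit). So compound 2 can be placed only at that limit and cannot be ranked against compound 1.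

The next compound, compound 3 `C/C(=C\CC/C(C)=C/CC[C@@H]1[C@@]2(C)CCC(=O)C(C)(C)[C@H]2CC[C@@]1(C)O)CC/C=C(\C)C(=O)OCc1cn(-c2ccc(C(C)(C)C)cc2)nn1`, puts tert-butyl in place of chloro on an aromatic carbon, para to a large group: tert-butyl in place of chloro on an aromatic carbon. The 4-chlorophenyl becomes 4-(tert-butyl)phenyl.

For the measured compounds named here, only one measured step bears on this. It also concerns the aryl group on the aromatic nitrogen, and it is a step that the two limits leave unreadable from compound 1 to compound 2. That step has no readable size, so there is no measured shift to carry over and no direction to predict in this assay. A change beyond the usual scatter is therefore not expected, and a further limit is the most likely report.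

The expected change is a number no higher from compound 2 to compound 3 (the limit leaves the size open). For compound 3 the estimate is 150000 nM, with an expected range of 70000 nM to 300000 nM.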

Compound 3, half-maximal inhibitory concentration: > 150000 nM
Compound 3 ended at the assay's limit; the forecaster's own chance of this, stated with the estimate: 70%; the middle value sits exactly at the limit.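

No step between compound 1, compound 2 and compound 3 can be read, since each carries only a limit and none can be ranked against another: the limit of > 150000 nM in this assay, at which 3 of the 3 values shown sit.

The compounds shown leave open what number any of the three would have, and so whether changing the aryl group on the aromatic nitrogen makes any difference in this assay.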